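The source may report more compounds than this note shows. Statements on the series, on what has been measured and on what is new or still open speak of the compounds shown alone.

Working notes on the series. Values are from an ADME assay on MCF-10A cells (Homo sapiens) for inhibition, with a stated time of 48 h (on this read-out higher numbers stand for weaker inhibition and lower numbers for stronger inhibition), and each is a limit of the assay, not a number.

- Compound 1 `O=C(Nc1ccc(Br)cc1)N1CCC[C@H]1c1nc(-c2ccccc2)no1`: > 50000 nM
- Compound 2 `O=C(Nc1ccc(I)cc1)N1CCC[C@H]1c1nc(-c2ccccc2)no1`: > 50000 nM
- Compound 3 `O=C(Nc1ccc(C(F)(F)F)cc1)N1CCC[C@H]1c1nc(-c2ccccc2)no1`: > 50000 nM

Compound 3 has no numerical position in the series. Its entry of > 50000 nM is a limit. The other two entries are limits too, and the whole set is summed up as the limit of > 50000 nM in this assay, at which 3 of the 3 values shown sit.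

The next compound is compound 4 `N#Cc1ccc(NC(=O)N2CCC[C@H]2c2nc(-c3ccccc3)no2)cc1`, which has cyano in place of trifluoromethyl on an aromatic carbon, para to a large group: cyano in place of trifluoromethyl on an aromatic carbon.

Three measured steps change the same aromatic carbon: a step that the two limits leave unreadable from compound 1 to compound 2, a step that the two limits leave unreadable from compound 1 to compound 3 and a step that the two limits leave unreadable from compound 2 to compound 3. None of them has a readable size, so none gives a magnitude or direction to carry over. Bromo, iodo and trifluoromethyl all leave the compounds at the limit in this assay, and none of the three compounds goes against this. Among the measured compounds shown here, the same outcome is therefore expected for cyano, although no measured step tests that group.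

The expected change is a number no higher from compound 3 to compound 4 (the limit leaves the size open), with no step beyond the scatter and no direction anticipated.

For compound 4, the estimated value is 50000 nM, with an expected range of 20000 nM to 100000 nM.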

Compound 4, half-maximal inhibitory concentration: > 50000 nM
Compound 4: only a limit was reported (the forecaster's own chance of this, stated with the estimate: 85%); the middle value lies on the limit itself.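

No new step can be read: the steps linking compound 4 with compound 1, compound 2 and compound 3 all run between limits, and their sizes stay unreadable. The series remains at a single entry: the limit of > 50000 nM in this assay, at which 4 of the 4 values shown sit.

The compounds shown leave open what numerical value any of them has, and whether bromo, iodo, trifluoromethyl and cyano differ at all on this read-out.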